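The compounds below may be only part of what the source reports. "The series", "measured", "known", "first", "only" and "open" are said of these compounds alone.

Compound 1 `Oc1cccc(-c2cc(-c3cccnc3)nc(-c3cccc(Cl)c3)c2)c1` gives 27.6% in an assay on isolated protein for inhibition of DNA topoisomerase 1 (Homo sapiens), with a stated time of 30 min, tested at 100 uM (on this read-out higher numbers stand for a stronger effect at the one concentration tested and lower numbers for a weaker effect), the highest of the three numbers shown, although compound 2 `Oc1ccc(-c2cc(-c3ccc(Cl)cc3)nc(-c3cccnc3)c2)cc1` with 18.8% lies within the usual scatter of it. Among the compounds with values here, compound 3 `Oc1cccc(-c2cc(-c3ccncc3)nc(-c3cccc(Cl)c3)c2)c1` gives 0%, and the step of a number 27.6 percentage points lower from compound 1 to compound 3 (beyond the scatter) is the only measured change among the three. Compound 4 `Oc1cccc(-c2cc(-c3cccnc3)nc(-c3ccccc3Cl)c2)c1` differs from compound 1 by 2-chlorophenyl in place of 3-chlorophenyl on an aromatic carbon. Within the data shown here, that single measured step concerns the pyridinyl group, not the chlorophenyl group, so no measured step bears on this change. Compound 4 is therefore expected to stay close to compound 1, with a number 5.6 percentage points lower from compound 1 to compound 4 (within the scatter) not beyond the scatter, and an estimated value of 22% in this assay, ranging from 5% to 40%.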

Compound 4, a percentage reported as inhibition, at one concentration (the size of the read-out at that concentration, not a potency): 0%
Compound 4: the middle estimate sits 22 percentage points above what was measured, and the stated range ends above it.
By their numbers in this assay, from the lowest: compounds 3 and 4 (each within the scatter of the next); then compounds 2 and 1 (each within the scatter of the next).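

The position of the chlorine on this phenyl group matters: in this assay 2-chlorophenyl in place of 3-chlorophenyl gives a number 27.6 percentage points lower from compound 1 to compound 4 (beyond the scatter) even though both groups hold the same atoms. Within the data shown here, earlier, only a change in the pyridinyl group had produced a step beyond the scatter, so this is the first such step at the chlorophenyl group. Nothing available accounts for this loss.

The compounds shown leave open whether a methoxy group or an amine in place of the chlorine would keep a number near that of compound 1, and how 4-chlorophenyl would read with the rest of compound 1 unchanged.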